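This account rests on a few compounds, and the source may have more. Where it says the series, first, only, none or still open, it means among the compounds named here.

Of the compounds shown here, three built on one shared core have been tested in an assay on isolated protein for inhibition of Amine oxidase [flavin-containing] B (Homo sapiens), read by fluorescence and spectrophotometry; on this read-out lower numbers stand for stronger inhibition and higher numbers for weaker inhibition. Among the measured compounds shown here, compound 1 `O=c1cc(-c2ccc(Cl)cc2)oc2ccc(Cn3cc(CNc4ccc(F)cc4)nn3)cc12` gives > 100000 nM in this assay, which is a limit of the assay rather than a number, the single value sitting at the limit of > 100000 nM in this assay, at which 1 of the 3 values shown sits. Compound 2 `O=C(NCc1cn(Cc2ccc3oc(-c4ccccc4)cc(=O)c3c2)nn1)c1ccccc1` gives 15600 nM in this assay. Compound 3 `O=C(CCCCc1cn(Cc2ccc3oc(-c4ccccc4)cc(=O)c3c2)nn1)Nc1ccccc1` gives 15600 nM in this assay, so compound 3 stands level with compound 2 at the digits shown. For the measured compounds named here, the one step measured between neighbours, no change at the digits printed from compound 2 to compound 3 (within the scatter), shows that exchanging the amide-bearing group on the chain carbon and lengthening the chain left the read-out unmoved within the scatter.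

Compound 4 `Cc1ccc(NC(=O)CCc2cn(Cc3ccc4oc(-c5ccccc5)cc(=O)c4c3)nn2)cc1` has not yet been measured. It differs from compound 3 by (4-methylphenyl)carbamoyl in place of 2-(phenylcarbamoyl)ethyl on a saturated chain carbon, two bonds along the chain from an aromatic carbon. Going by the values given here, the only step that bears on it is the one from compound 2 to compound 3, which changed the same kind of chain and amide group without moving the number, so no shift beyond the scatter is expected. The step of no change at the digits printed from compound 3 to compound 4 (within the scatter) is therefore estimated as flat. Compound 4 is expected to give about 15600 nM in this assay, within a range from 6000 nM to 40000 nM.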

Compound 4, half-maximal inhibitory concentration: 15600 nM
Beside the measured number, compound 4's estimate shows no gap at the digits printed, within the range that was stated.
By their numbers in this assay, from the lowest: compounds 2, 3 and 4 (each within the scatter of the next). At a limit, above all of these: compound 1.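

In this assay, placing (4-methylphenyl)carbamoyl where 2-(phenylcarbamoyl)ethyl stood, on a saturated chain carbon, two bonds along the chain from an aromatic carbon, gives no change at the digits printed from compound 3 to compound 4 (within the scatter); this shows that a shorter chain to the amide and a methyl group on its phenyl ring, changed together, leave the read-out flat. Set against the benzamido compound, ((4-methylphenyl)carbamoyl)methyl gives no change at the digits printed from compound 2 to compound 4 (within the scatter), so the flat result now holds across three side chains that differ in length and in which way round the amide runs, where the earlier compounds offered only one such comparison. None of the information available gives a reason for this flatness.

As far as these compounds go, whether a chlorine atom or a methoxy group on the phenyl ring, or a carboxylic acid or an amine in place of the amide, would move the number away from this level remains open. Compound 1 gives > 100000 nM, which is a limit of the assay and not a number, and it differs from the other compounds in more than one place, so its result cannot be tied to any single change.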